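The source may hold more compounds than are shown below. What is called first, only, known or untested is meant among the compounds shown, and "the series" means these compounds.

Compound 1 `CCC(=O)Nc1ccc(N2CCN(c3ccc(OC[C@@H]4CO[C@@](Cn5cncn5)(c5ccc(Cl)cc5Cl)O4)cc3)CC2)cc1` and compound 2 `O=C(Nc1ccc(N2CCN(c3ccc(OC[C@@H]4CO[C@@](Cn5cncn5)(c5ccc(Cl)cc5Cl)O4)cc3)CC2)cc1)c1ccc(F)c(F)c1` share one core and differ only in the group on a carbonyl carbon. In a toxicity assay on L02 cells (Homo sapiens) for inhibition, read by MTT assay, with a stated time of 48 h (on this read-out higher numbers stand for weaker inhibition and lower numbers for stronger inhibition), compound 1 gives no number but a limit of the assay, > 50000 nM. In this assay compound 2 likewise gives only a limit, > 50000 nM. The step that the two limits leave unreadable from compound 1 to compound 2 therefore cannot be read in size; both values sit at the limit of > 50000 nM in this assay, at which 2 of the 2 values shown sit. Compound 3 `Cc1ccc(C(=O)Nc2ccc(N3CCN(c4ccc(OC[C@@H]5CO[C@@](Cn6cncn6)(c6ccc(Cl)cc6Cl)O5)cc4)CC3)cc2)o1` differs from compound 2 in one place: 5-methylfuran-2-yl in place of 3,4-difluorophenyl on a carbonyl carbon. Among the compounds with values here, the single measured step in this assay, from compound 1 to compound 2, also exchanged the group on that carbonyl carbon, and it stayed unreadable because both values sat at the limit of > 50000 nM in this assay, at which 2 of the 2 values shown sit. Since compound 2 itself stands at the limit, the change to compound 3 is expected to leave compound 3 at the same limit, so the step that the limit leaves unreadable from compound 2 to compound 3 is expected to show nothing beyond the scatter. Compound 3 is therefore estimated at 60000 nM, with a range from 25000 nM to 200000 nM, and most likely reported once more only as a limit.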

Compound 3, half-maximal inhibitory concentration: > 50000 nM
Compound 3: no number, only a limit (the forecaster's own chance of this, stated with the estimate: 85%); the middle value is on the limit's open side.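

In this assay compound 3 also gives only a limit of the assay, > 50000 nM. The steps among compound 1, compound 2 and compound 3 therefore cannot be read in size: the limit of > 50000 nM in this assay, at which 3 of the 3 values shown sit. Left open is where the true value of each compound lies, and whether the group on the carbonyl carbon changes it at all.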